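Ester Cleavage on an Inactive Core: Compound 3 Expected

This account rests on a few compounds, and the source may have more. Where it says the series, first, only, none or still open, it means among the compounds named here.

compound 1 `CCOC(=O)c1c(C)oc2ncnc(Nc3cccc(C)c3)c12`: > 1000000 nM
compound 2 `C#Cc1cccc(Nc2ncnc3oc(C)c(C(=O)OCC)c23)c1`: > 1000000 nM

In a functional assay on A549 cells (Homo sapiens) for cytotoxicity, read by MTT assay, with a stated time of 72 h (a higher number here means a weaker inhibitor, a lower number a stronger inhibitor), compound 1 gives > 1000000 nM, which is a limit of the assay rather than a number. In this assay compound 2 gives > 1000000 nM, also a limit. The step that the two limits leave unreadable from compound 1 to compound 2 therefore cannot be sized because of the limit of > 1000000 nM in this assay, at which 2 of the 2 values shown sit. Compound 3 `Cc1cccc(Nc2ncnc3oc(C)c(C(=O)O)c23)c1` differs from compound 1 by hydrogen in place of ethyl on an oxygen next to a carbonyl group. Within the data shown here, no measured step changes the ethoxycarbonyl group, and compound 1 only sets a limit, so compound 3 is expected to remain near that limit, with a step of a number no higher from compound 1 to compound 3 (the limit leaves the size open) not expected to exceed the scatter. Compound 3 is estimated at 1000000 nM, ranging from 200000 nM to 5000000 nM.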

Compound 3, half-maximal inhibitory concentration: 100000 nM
Compound 3: middle estimate off by 10-fold (1.00 log units), on the high side; measured number outside the range, below it.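

In this assay, hydrogen in place of ethyl on an oxygen next to a carbonyl group, which turns ethoxycarbonyl into carboxy, gives an at least 10-fold lower number from compound 1 to compound 3 (1.00 log units; beyond the scatter). This is the first readable change among these compounds, since the step from methyl to ethynyl cannot be read. The full size of the new step stays open because compound 1 gives only a limit: the limit of > 1000000 nM in this assay, at which 2 of the 3 values shown sit.

Still open, going by these compounds, is how an amide or a methyl ester would read in place of the carboxy group. It is also unknown whether the same change would lower the number for compound 2.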